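A few compounds are considered here, and "the series" means these few. Any claim that something is new, unique, unknown or untested is made for them only; others in the source may bear on it.

Compound 1 `N#Cc1c(N)[n+]([O-])c2ccc(Cl)cc2[n+]1[O-]` gives in a functional assay on Ehrlich cells (Mus musculus) for cytotoxicity, read by trypan blue exclusion, with a stated time of 2 h, tested at 1 ug/mL (on this read-out higher numbers stand for a weaker effect at the one concentration tested and lower numbers for a stronger effect), a value of 100%. Compound 2 `CNc1c(C#N)[n+]([O-])c2cc(Cl)ccc2[n+]1[O-]` gives in this assay a value of 100%. The only measured step, no change at the digits printed from compound 1 to compound 2 (within the scatter), leaves compound 2 level with compound 1 at the digits shown. Compound 3 `CC(=O)N(C(C)=O)c1c(C#N)[n+]([O-])c2cc(Cl)ccc2[n+]1[O-]` differs from compound 2 by diacetylamino in place of methylamino on an aromatic carbon. For the measured compounds named here, no measured step covers a change of this kind; the one step available, on a nitrogen on an aromatic ring, left the read-out unmoved. Compound 3 is therefore expected to stay near the same level, with a step of a number 2 percentage points lower from compound 2 to compound 3 (within the scatter) in this assay. The estimate for compound 3 is 98%, expected to lie between 80% and 100%.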

Compound 3, a percentage reported as activity, at one concentration (the size of the read-out at that concentration, not a potency): 99.6%
Compound 3: the middle estimate sits 1.6 percentage points below what was measured; the measured number falls inside the stated range.
By their numbers in this assay, from the lowest: compounds 3, 1 and 2 (each within the scatter of the next).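

Diacetylamino in place of methylamino on the aromatic carbon next to the ring nitrogen gives a number 0.4 percentage points lower from compound 2 to compound 3 (within the scatter) in this assay, and diacetylamino in place of amino gives a number 0.4 percentage points lower from compound 1 to compound 3 (within the scatter). This position therefore accepts a larger group with 0 hydrogen-bond donors, and the read-out stays level at the one concentration tested. Nothing available explains this flat result. Open, on these data alone, is whether any other group here, such as a carboxylic acid or a longer alkylamino chain, moves the read-out. Also open, as far as these compounds go, is whether the shared core can give a stronger effect at all.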